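Replacing Pyrrolidin-1-yl with 4-Methylpiperazin-1-yl in Compound 1

This account rests on a few compounds, and the source may have more. Where it says the series, first, only, none or still open, it means among the compounds named here.

In a functional assay on BXPC-3 cells (Homo sapiens) for cytotoxicity, read by fluorescence, with a stated time of 48 h (on this read-out lower numbers stand for an effect already at smaller amounts and higher numbers for an effect only at larger amounts of compound), compound 1 `CC(C)=CCC/C(C)=C/CC/C(C)=C/CSC[C@H](NC(=O)CCCCCN1CCCC1)C(=O)NC1CCCC1` gives 6800 nM. This number lies within the scatter of those for compound 2 `CC(C)=CCC/C(C)=C/CC/C(C)=C/CSC[C@H](NC(=O)CCCCCN1CCN(C)CC1)C(=O)NC1CCCCCCC1`, at 7500 nM, and compound 3 `CC(C)=CCC/C(C)=C/CC/C(C)=C/CSC[C@H](NC(=O)CCCCCN1CCCC1)C(=O)NC1CCCCCC1`, at 5800 nM. Compound 4 `CC(C)=CCC/C(C)=C/CC/C(C)=C/CSC[C@H](NC(=O)CCCCCN1CCN(C)CC1)C(=O)NC1CCCC1` is still unmeasured, and its difference from compound 1 is this: 4-methylpiperazin-1-yl in place of pyrrolidin-1-yl on a saturated chain carbon, five bonds along the chain from a carbonyl carbon. Within the data shown here, no measured step covers this swap directly. Among the measured compounds shown here, the one measured step, a 1.2-fold lower number from compound 1 to compound 3 (0.07 log units; within the scatter), concerns the ring on an amide-type nitrogen and stays within the scatter. Compound 2 carries 4-methylpiperazin-1-yl with a different ring on that nitrogen and gives 7500 nM, so no step beyond the scatter is expected in this assay. The expected step is a 1.0-fold higher number from compound 1 to compound 4 (0.01 log units; within the scatter). For compound 4 the estimate is 7000 nM, with an expected range of 3500 nM to 14000 nM.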

Compound 4, half-maximal effective concentration: > 20000 nM
Compound 4: only a limit was reported (the forecaster's own chance of this, stated with the estimate: 5%); at least 2.8-fold (0.45 log units) between middle value and limit.
By their numbers in this assay, from the lowest: compounds 3, 1 and 2 (each within the scatter of the next). At a limit, above all of these: compound 4.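

In this assay compound 4 gives > 20000 nM, which is a limit and not a number. Among these compounds, at this place on the chain, the ring swap therefore counts, with an at least 2.9-fold higher number from compound 1 to compound 4 (0.46 log units; beyond the scatter), something the earlier compounds did not reveal. With 4-methylpiperazin-1-yl present, the ring on the amide-type nitrogen counts too, as cyclopentyl in place of cyclooctyl gives an at least 2.6-fold higher number from compound 2 to compound 4 (0.42 log units; beyond the scatter).

Still open, as far as these compounds go, is how piperidin-1-yl or an unmethylated piperazin-1-yl would behave at this place. The compounds shown also leave open whether a longer chain would carry the same difference.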